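Removing a fluorine from the aromatic ring of compound 1

A few compounds are considered here, and "the series" means these few. Any claim that something is new, unique, unknown or untested is made for them only; others in the source may bear on it.

Among the compounds with values here, compound 1 `C=C/C=C\[C@H](C)[C@H](OC(N)=O)[C@@H](C)[C@H](O)[C@@H](C)C/C(C)=C\[C@H](C)[C@@H](O)[C@@H](C)/C=C\CCc1cccc(F)c1` is tested in a functional assay on MCF7 cells (Homo sapiens) for cytotoxicity (a lower number here means a stronger inhibitor, a higher number a weaker inhibitor), and gives 370 nM, the lowest of the two numbers known so far. Its closest neighbour is compound 2 `C=C/C=C\[C@H](C)[C@H](OC(N)=O)[C@@H](C)[C@H](O)[C@@H](C)C/C(C)=C\[C@H](C)[C@@H](O)[C@@H](C)/C=C\CCc1cccc(O)c1C`, which in this assay gives 490 nM; the step of a 1.3-fold higher number from compound 1 to compound 2 (0.12 log units; within the scatter) swaps the 3-fluorophenyl for a 3-hydroxy-2-methylphenyl and changes the number only within the scatter. The unmeasured compound 3 `C=C/C=C\[C@H](C)[C@H](OC(N)=O)[C@@H](C)[C@H](O)[C@@H](C)C/C(C)=C\[C@H](C)[C@@H](O)[C@@H](C)/C=C\CCc1ccccc1` differs from compound 1 by hydrogen in place of fluoro on an aromatic carbon, on an aromatic carbon of a six-membered aromatic ring of carbon only. Within the data shown here, only the step from compound 1 to compound 2 bears on this, and it shows that altering the groups on this ring barely moves the number. The same is therefore expected here: compound 3 is estimated at 450 nM with a range of 200 nM to 1000 nM, meaning an expected step of a 1.2-fold higher number from compound 1 to compound 3 (0.09 log units; within the scatter), not beyond the scatter.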

Compound 3, half-maximal inhibitory concentration: 480 nM
Beside the measured number, compound 3's estimate is 1.1-fold (0.03 log units) below it; the measured number falls inside the stated range.
By their numbers in this assay, from the lowest: compounds 1, 3 and 2 (each within the scatter of the next).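

In this assay, removing the fluoro group from the ring gives a 1.3-fold higher number from compound 1 to compound 3 (0.11 log units; within the scatter), so the fluorine on this aromatic carbon is not needed to keep the number where it stands. The plain phenyl also cannot be told apart from the more heavily substituted ring, with a 1.0-fold lower number from compound 2 to compound 3 (0.01 log units; within the scatter), which means that compounds 1, 2 and 3 show no measurable gain from either set of ring groups in this read-out. Nothing measured here explains why these changes leave the number in place.

Going by these compounds, it remains open whether the number would hold with a different kind of group on this ring, such as an amine or a carboxylic acid. Also open, on these data alone, is whether a longer chain in place of the phenethyl would move the number.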